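Isomeric thienopyrimidine ethers on a shared aminopyrimidine core

The source may hold more compounds than are shown below. What is called first, only, known or untested is meant among the compounds shown, and "the series" means these compounds.

Measured compounds:
compound 1, `c1cc(N2CCCC2)nc(Nc2ccc(Oc3ncnc4ccsc34)cc2)n1`, "not active" (no number reported) in a functional assay on A549 cells (Homo sapiens) for inhibition, read by MTT assay, with a stated time of 72 h; on this read-out lower numbers stand for stronger inhibition and higher numbers for weaker inhibition
compound 2, `c1ccc2c(c1)CCN(c1ccnc(Nc3ccc(Oc4ncnc5ccsc45)cc3)n1)C2`, 17000 nM
compound 3, `c1cc(N2CCCCC2)nc(Nc2ccc(Oc3ncnc4ccsc34)cc2)n1`, 7800 nM

Compound 1 stands apart from the other two: in this assay compound 1 is reported only as "not active" (no number reported), with no number attached, so it cannot be placed on the same scale as compound 2 or compound 3. Among the compounds with values here, the one step that has been measured, a 2.2-fold lower number from compound 2 to compound 3 (0.34 log units; beyond the scatter), concerns a different part of the molecule and does not bear on the change now considered.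

Compound 4, `c1cc(N2CCCC2)nc(Nc2ccc(Oc3ncnc4sccc34)cc2)n1`, differs from compound 1 as follows: a group of 9 heavy atoms (6 carbon, 2 nitrogen, 1 sulfur; one five-membered aromatic ring with 1 hetero atom, one six-membered aromatic ring with 2 hetero atoms) in place of a group of 9 heavy atoms (6 carbon, 2 nitrogen, 1 sulfur; one five-membered aromatic ring with 1 hetero atom, one six-membered aromatic ring with 2 hetero atoms), on an oxygen on an aromatic ring. Within the data shown here, since compound 1 carries no number, no step from it can be sized, and nothing among the measured pairs speaks to this kind of rearrangement. The expectation therefore rests only on compound 1 showing no activity in this assay, which makes a weak result the likely outcome, with a fair chance that again only a limit is reported.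

Compound 4 is estimated to give 30000 nM in this assay, expected within 8000 nM to 100000 nM.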

Compound 4, half-maximal inhibitory concentration: 8100 nM
Estimate against measurement, compound 4: 3.7-fold (0.57 log units) above; low and high end bracket the measured number.
By their numbers in this assay, from the lowest: compounds 3 and 4 (each within the scatter of the next); then compound 2.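

With no number for compound 1 in this assay the change to compound 4 cannot be sized as a step. Nothing shown offers an explanation for the result of compound 4. The compounds shown leave open whether the same exchange would shift the numbers of compound 2 or compound 3.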